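Next Step from the Azido Compound

A few compounds are considered here, and "the series" means these few. Any claim that something is new, unique, unknown or untested is made for them only; others in the source may bear on it.

In a functional assay on HL-60 cells (Homo sapiens) for antiproliferative activity, read by MTT assay, with a stated time of 48 h (a lower number here means a stronger inhibitor, a higher number a weaker inhibitor), compound 2 `CC(C)=CCC[C@]1(C)/C=C/[C@@H](OC(=O)C=C(C)C)[C@](C)(O)/C=C/C(=O)/C(CN=[N+]=[N-])=C\C1` gives 910 nM and holds the lower of the two numbers, while compound 1 `CC(C)=CCC[C@]1(C)/C=C/[C@@H](OC(=O)C=C(C)C)[C@](C)(O)/C=C/C(=O)/C(C[Si](C)(C)C(C)(C)C)=C\C1` gives 2770 nM on the same core. Compound 3 `CSC(=S)OC/C1=C/C[C@](C)(CCC=C(C)C)/C=C/[C@@H](OC(=O)C=C(C)C)[C@](C)(O)/C=C/C1=O` differs from compound 2 by a group of 5 heavy atoms (2 carbon, 1 oxygen, 2 sulfur; no ring) in place of a group of 3 heavy atoms (3 nitrogen; no ring), on a saturated chain carbon bound to a double-bonded ring carbon and nothing else. Within the data shown here, the only measured step bearing on this is a 3.0-fold lower number from compound 1 to compound 2 (0.48 log units; beyond the scatter) and it is modest, with the smaller group on the lower side. Among the measured compounds shown here, the entering group falls between those two groups in heavy-atom count, and no measured compound carries it. A modest rise is therefore expected, a 2.2-fold higher number from compound 2 to compound 3 (0.34 log units; beyond the scatter) as estimated. For compound 3 the estimate is 2000 nM with an expected range of 700 nM to 5000 nM for now.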

Compound 3, half-maximal inhibitory concentration: 180 nM
Compound 3: the middle estimate sits 11-fold (1.05 log units) above what was measured; measured number outside the range, below it.
By their numbers in this assay, from the lowest: compound 3; then compound 2; then compound 1.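

At this saturated chain carbon bound to a double-bonded ring carbon, heavy-atom count does not order the numbers in this assay: the larger group gives a 5.1-fold lower number from compound 2 to compound 3 (0.70 log units; beyond the scatter), while the same group against the largest gives a 15-fold lower number from compound 1 to compound 3 (1.19 log units; beyond the scatter). The smaller-is-lower reading of the earlier step therefore fails, as the group of middle size now holds the lowest number. No supporting data bear on the reason for this.

As far as these compounds go, whether the change follows the sulfur atoms, the oxygen or the whole group remains open. An amine or an acetate ester on the same carbon would help separate these.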